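The source may hold more compounds than are shown below. What is called first, only, known or untested is meant among the compounds shown, and "the series" means these compounds.

Three compounds sharing one core have been examined in a functional assay on MOLT-4 cells (Homo sapiens) for cytotoxicity, with a stated time of 72 h; a lower number here means a stronger inhibitor, a higher number a weaker inhibitor. In this assay compound 1 `Cc1ccc(/C=C2\CCC/C(=C\c3ccc([N+](=O)[O-])cc3)C2=O)cc1` gives 8440 nM. In this assay compound 2 `Cc1ccc(/C=C2\CCC/C(=C\c3cccc([N+](=O)[O-])c3)C2=O)cc1` gives 9530 nM, and compound 3 `CN(C)c1ccc(/C=C2\CCC/C(=C\c3ccccc3[N+](=O)[O-])C2=O)cc1` gives 122000 nM. Among these three numbers compound 2 stands second highest; its nearest neighbour is compound 1, whose number lies within the usual scatter of such measurements, while compound 3 lies farthest from it, with a number that is higher than that of compound 2 and beyond the scatter.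

The unmeasured compound 4 `O=C1/C(=C/c2ccccc2)CCC/C1=C\c1cccc([N+](=O)[O-])c1` differs from compound 2 in one place: hydrogen in place of methyl on an aromatic carbon. For the measured compounds named here, no pair of measured compounds separated by exactly this change is available, so the size of the step must be judged from the change itself. With only a methyl leaving and hydrogen entering, the step in this assay is expected to stay within the scatter, with no clear direction: a 1.0-fold lower number from compound 2 to compound 4 (0.00 log units; within the scatter). Compound 4 is therefore expected to give about 9500 nM in this assay, within a range from 4000 nM to 25000 nM.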

Compound 4, half-maximal inhibitory concentration: 1700 nM
The estimate for compound 4 lay 5.6-fold (0.75 log units) above the measured number; measured number below the stated range.
By their numbers in this assay, from the lowest: compound 4; then compounds 1 and 2 (each within the scatter of the next); then compound 3.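

In this assay, the change from 4-methylphenyl to phenyl gives a 5.6-fold lower number from compound 2 to compound 4 (0.75 log units; beyond the scatter), so even the loss of a single methyl at this aromatic carbon, para to a large group, moves the number beyond the scatter. The earlier compounds shown here all carried a group at this place, so none of them showed how the unsubstituted phenyl behaves. Nothing at hand explains why the number falls once the methyl is gone.

Going by these compounds, whether a methoxy group, a chlorine atom, an ethyl group or a carboxylic acid at this place would give a number closer to that of compound 2 or of compound 4 remains open. This single step also leaves open whether the same change would have a similar effect in a compound whose nitro group sits elsewhere.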